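This account rests on a few compounds, and the source may have more. Where it says the series, first, only, none or still open, it means among the compounds named here.

Within the data shown here, compound 2 `CNC(=O)/C=C/c1ccc(NC(=O)Nc2ccc(Cl)c(C(F)(F)F)c2)cc1` is the reference point here: in a functional assay on MX1 cells (Homo sapiens) for inhibition, read by MTT assay, with a stated time of 120 h (a higher number here means a weaker inhibitor, a lower number a stronger inhibitor), compound 2 gives 13800 nM and sits at the upper end of the three numbers known so far. Compound 3 `CC1CN(C(=O)/C=C/c2ccc(NC(=O)Nc3ccc(Cl)c(C(F)(F)F)c3)cc2)CC(C)O1` gives 12800 nM and cannot be told apart from it (a 1.1-fold lower number from compound 2 to compound 3 (0.03 log units; within the scatter)). Compound 1 `CC(NC(=O)/C=C/c1ccc(NC(=O)Nc2ccc(Cl)c(C(F)(F)F)c2)cc1)c1ccccc1` gives 3130 nM and stands clearly lower (a 4.4-fold higher number from compound 1 to compound 2 (0.64 log units; beyond the scatter)).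

Compound 4 `CNC(=O)/C=C(\C)c1ccc(NC(=O)Nc2ccc(Cl)c(C(F)(F)F)c2)cc1` departs from compound 2 in one place, with 1-methyl-2-(methylcarbamoyl)ethenyl in place of 2-(methylcarbamoyl)ethenyl on an aromatic carbon, para to a large group (1-methyl-2-(methylcarbamoyl)ethenyl in place of 2-(methylcarbamoyl)ethenyl on an aromatic carbon). Among the measured compounds shown here, none of the measured steps makes this change. All three alter only what sits on the amide carbonyl, and the two that exceed the scatter, a 4.4-fold higher number from compound 1 to compound 2 (0.64 log units; beyond the scatter) and a 4.1-fold higher number from compound 1 to compound 3 (0.61 log units; beyond the scatter), were modest even though they exchange much larger groups. They set a rough scale but give no direction for a methyl group added to the ethenyl unit. In this assay, therefore, no step beyond the scatter is expected, and the expected change is only a 1.2-fold lower number from compound 2 to compound 4 (0.06 log units; within the scatter) with the uncertainty left wide on both sides. Compound 4 is estimated at 12000 nM (expected range 4500 nM to 30000 nM).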

Compound 4, half-maximal inhibitory concentration: > 50000 nM
Compound 4 was reported as a limit (the forecaster's own chance of this, stated with the estimate: 10%); middle value at least 4.1-fold (0.61 log units) away from the limit.
By their numbers in this assay, from the lowest: compound 1; then compounds 3 and 2 (each within the scatter of the next). At a limit, above all of these: compound 4.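

Among these compounds, the measured steps had so far touched only what sits on the amide carbonyl, and the new result, an at least 3.6-fold higher number from compound 2 to compound 4 (0.55 log units; beyond the scatter) in this assay, shows that the group on the aromatic carbon, para to a large group, is also a place where a change moves the number beyond the scatter. The step runs toward a weaker inhibitor, although 2-(methylcarbamoyl)ethenyl and 1-methyl-2-(methylcarbamoyl)ethenyl differ only by the added methyl group and carry the same count of hydrogen-bond donors and acceptors and no net charge. Compound 4 stands only as a limit, so the step marks the least the change can be and not its actual size: the limit of > 50000 nM in this assay, at which 1 of the 4 values shown sits.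

Going by these compounds, whether an ethyl group or a fluorine in place of the added methyl would move the number in the same way remains open. Also open, on these data alone, is whether the 1-phenylethyl amide of compound 1, which gives 3130 nM in this assay, would respond to the added methyl group as compound 2 does.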